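Cyclohexyl for methoxybenzyl on the imidazole carbon of a biphenyl acid

The compounds below may be only part of what the source reports. "The series", "measured", "known", "first", "only" and "open" are said of these compounds alone.

Measured so far:
compound 1, `COc1ccccc1Cc1cnc(CCc2ccc(-c3ccccc3C(=O)O)cc2)[nH]1`, 1720 nM
compound 2, `CCCCc1cnc(CCCc2ccc(-c3ccccc3C(=O)O)cc2)[nH]1`, 5600 nM

The two compounds were tested in an in vitro functional assay on cells for agonist activity at Bombesin receptor subtype-3 (Homo sapiens), read by luminescence and calcium flux; on this read-out lower numbers stand for an effect already at smaller amounts and higher numbers for an effect only at larger amounts of compound. Compound 1 gives 1720 nM, the lowest of the two numbers; compound 2 gives 5600 nM, a higher number that lies beyond the usual scatter, so compound 1 stands as the more potent of the pair. Among the measured compounds shown here, compound 2 differs from compound 1 in more than one place, so the two values show only that compound 1 sits lower.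

Compound 3, `O=C(O)c1ccccc1-c1ccc(CCc2ncc(C3CCCCC3)[nH]2)cc1`, has not yet been measured. It differs from compound 1 in one place: cyclohexyl in place of 2-methoxybenzyl on an aromatic carbon. For the measured compounds named here, no measured pair isolates this change, so nothing in the data fixes its size. Because compound 1 already gives 1720 nM and the entering group is smaller and lacks the acceptor of the group that leaves, a modest loss is expected rather than a gain, and the step from compound 1 to compound 3 in this assay is estimated at a 2.0-fold higher number from compound 1 to compound 3 (0.31 log units; beyond the scatter). Compound 3 is therefore expected to give about 3500 nM in this assay, in a range from 1200 nM to 10000 nM.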

Compound 3, half-maximal effective concentration: 375 nM
For compound 3 the middle estimate is 9.3-fold (0.97 log units) above the measured one; the measured number lies below the stated range.
By their numbers in this assay, from the lowest: compound 3; then compound 1; then compound 2.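

In this assay, the aromatic carbon of the five-membered ring with 2 nitrogen proves sensitive to the group it carries: cyclohexyl in place of 2-methoxybenzyl gives a 4.6-fold lower number from compound 1 to compound 3 (0.66 log units; beyond the scatter), and compound 3, at 375 nM, has the lowest number of the three compounds. The change therefore shows that neither the aromatic ring nor the hydrogen-bond acceptor of the 2-methoxybenzyl group is required for a low number here, and that the 6 heavy atoms of cyclohexyl suffice where the group that leaves has 9. This one pair changes all of these features together, so it cannot say which of them accounts for the step, and no measurement at hand offers an explanation for it.

The compounds shown leave open how a plain phenyl, a cyclopentyl or a tert-butyl group would compare with cyclohexyl on this carbon, and whether a hydroxyl or an amine on the cyclohexyl ring would retain the lower number. Compound 2 differs from compound 3 in more than one place, so the standing of its butyl group at this position also remains unsettled.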